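The source may hold more compounds than are shown below. What is called first, only, known or untested is meant among the compounds shown, and "the series" means these compounds.

Working notes on the series. In a functional assay on MCF7 cells (Homo sapiens) for cytotoxicity, read by MTT assay, with a stated time of 48 h (a lower number here means a stronger inhibitor, a higher number a weaker inhibitor), compound 1 `CC(C)c1ccc(/C=C2/S/C(=N/c3ccccc3)N(Cc3ccncc3)C2=O)cc1` gives 53300 nM and compound 2 `COc1ccc(/C=C2/S/C(=N/c3ccccc3)N(Cc3ccncc3)C2=O)cc1OC` gives 80700 nM. These two values lie within the scatter of each other, so compound 2 stands level with compound 1. Compound 3 `O=C1/C(=C\c2cccc(Cl)c2)S/C(=N/c2ccccc2)N1Cc1ccncc1` keeps the shared core and carries 3-chlorophenyl in place of 3,4-dimethoxyphenyl on a double-bonded chain carbon bound to a double-bonded ring carbon. Going by the values given here, one measured step bears on this place, a 1.5-fold higher number from compound 1 to compound 2 (0.18 log units; within the scatter), and it stayed small. Among the compounds with values here, no compound with 3-chlorophenyl has yet been measured, so the evidence is thin and the range must stay wide. In this assay, the expected change is a 1.6-fold lower number from compound 2 to compound 3 (0.21 log units; within the scatter), with no step beyond the scatter anticipated. The estimate for compound 3 is 50000 nM, with an expected range of 17000 nM to 130000 nM.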

Compound 3, half-maximal inhibitory concentration: 29800 nM
Compound 3: the middle estimate sits 1.7-fold (0.22 log units) above what was measured, and the stated range covers the measured number.
By their numbers in this assay, from the lowest: compounds 3, 1 and 2 (each within the scatter of the next, the first and the last beyond it).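

In this assay, this place on a double-bonded chain carbon bound to a double-bonded ring carbon now shows a step beyond the scatter, with 3-chlorophenyl in place of 3,4-dimethoxyphenyl giving a 2.7-fold lower number from compound 2 to compound 3 (0.43 log units; beyond the scatter) where the earlier exchange stayed within it. Set against 4-isopropylphenyl, the same 3-chlorophenyl gives a 1.8-fold lower number from compound 1 to compound 3 (0.25 log units; within the scatter) and so stays within the scatter, which means only the pair with 3,4-dimethoxyphenyl is separated, and only modestly. Nothing at hand gives a cause for this step.

On these data alone, what a bare phenyl, or a phenyl carrying an amine or a carboxylic acid, would give at this place stays open, as does whether the chlorine or the loss of the two methoxy groups carries the step. As far as these compounds go, the rest of the shared core stays unchanged across these compounds, so its contribution also remains open.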